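Three Fluorinated Anilines at the Cytotoxicity Limit

A few compounds are considered here, and "the series" means these few. Any claim that something is new, unique, unknown or untested is made for them only; others in the source may bear on it.

Measured in a functional assay on Raji cells (Homo sapiens) for cytotoxicity, with a stated time of 72 h; a lower number here means that less compound is needed, a higher number that more compound is needed for the effect:
Compound 1 `C=C[C@@](C)(/C=C/c1ccc(Nc2cc(F)cc(F)c2)cc1)CCC=C(C)C`: > 26000 nM (a limit)
Compound 2 `C=C[C@@](C)(/C=C/c1ccc(Nc2ccc(Cl)c(F)c2)cc1)CCC=C(C)C`: > 26000 nM (a limit)

Compound 2 stands only at a limit, with no number, at > 26000 nM. Compound 3 `C=C[C@@](C)(/C=C/c1ccc(Nc2c(F)cc(F)cc2F)cc1)CCC=C(C)C` differs from compound 2 by 2,4,6-trifluorophenyl in place of 4-chloro-3-fluorophenyl on a nitrogen on an aromatic ring, with 2,4,6-trifluorophenyl in place of 4-chloro-3-fluorophenyl on a nitrogen on an aromatic ring. For the measured compounds named here, the one measured step that bears on this also changes the group at that place: a step that the two limits leave unreadable from compound 1 to compound 2. Its size cannot be read, as both compounds sit at the limit of > 26000 nM in this assay, at which 2 of the 2 values shown sit. No clear direction is therefore expected in this assay, and the estimated change is a step that the limit leaves unreadable from compound 2 to compound 3. Compound 3 is expected at 30000 nM, within an estimated range of 15000 nM to 60000 nM, and most likely again as a limit.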

Compound 3, half-maximal effective concentration: > 26000 nM
Compound 3 gave a limit, no number; the forecaster's own chance of this, stated with the estimate: 80%; the middle value is on the limit's open side.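

Compound 1, compound 2 and compound 3 all stand only at a limit in this assay, so no step among them can be read: the limit of > 26000 nM in this assay, at which 3 of the 3 values shown sit.

The compounds shown leave open whether the aryl group on the nitrogen changes the concentration needed in this assay.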